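Swapping One Phenyl Group on Compound 2

This account rests on a few compounds, and the source may have more. Where it says the series, first, only, none or still open, it means among the compounds named here.

Of the compounds shown here, two have numbers so far in an ADME assay on HepG2 cells (Homo sapiens) for cytotoxicity; a lower number here means that less compound is tolerated, a higher number that more compound is tolerated. Compound 1 `CSc1cccc(NC(=O)c2cc3ccc(C(F)(F)F)cc3n2CC(C)C(=O)NC2CCCC2)c1` gives 7100 nM, and compound 2 `CSc1cccc(N2C(=O)CN(c3ccc(C(F)(F)F)cc3)CC2C(=O)NC2CCCC2)c1` gives 10000 nM. These two values lie within the usual scatter of repeated measurements, so compound 2 stands level with compound 1 and neither can be ranked against the other. Among the compounds with values here, no two measured compounds differ in just one place, so no measured step is available as a guide.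

Compound 3 `CSc1cccc(N2C(=O)CN(c3cc(C(F)(F)F)ccc3C)CC2C(=O)NC2CCCC2)c1` matches compound 2 except at a single site: 2-methyl-5-(trifluoromethyl)phenyl in place of 4-(trifluoromethyl)phenyl on an amine nitrogen in a ring. The incoming group carries the same trifluoromethyl substituent and differs by a small count of atoms. Within the data shown here, with no measured example of such a swap, no shift beyond the scatter is expected in this assay, in either direction. Expressed as a change, the expected size is a 1.1-fold lower number from compound 2 to compound 3 (0.05 log units; within the scatter). The estimate for compound 3 is 9000 nM, with an expected range of 4000 nM to 20000 nM.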

Compound 3, half-maximal cytotoxic concentration: 10000 nM
Compound 3: the middle estimate sits 1.1-fold (0.05 log units) below what was measured, and the stated range covers the measured number.
By their numbers in this assay, from the lowest: compounds 1, 2 and 3 (each within the scatter of the next).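

Swapping 4-(trifluoromethyl)phenyl for 2-methyl-5-(trifluoromethyl)phenyl on the amine nitrogen in the ring gives, in this assay, no change at the digits printed from compound 2 to compound 3 (within the scatter). Within the data shown here, this is the first measured step in which only one place differs, and it shows that at this position the tolerated concentration of compound 3 stays level with that of compound 2 when the phenyl group gains a methyl and carries its trifluoromethyl at a different ring position. No measurement shown here explains why the number stays level.

The two alterations arrive together in this single step, so the effect of the methyl cannot be separated from that of the moved trifluoromethyl, and they could in principle offset each other. Going by these compounds, it also remains open whether the same level holds when something less similar sits on this nitrogen, such as a pyridine ring, an unsubstituted phenyl, a cyclohexyl group or a longer alkyl chain, since both groups compared here are trifluoromethyl-bearing phenyl rings.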